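Bulk on the Amine Nitrogen and Receptor Binding

A few compounds are considered here, and "the series" means these few. Any claim that something is new, unique, unknown or untested is made for them only; others in the source may bear on it.

compound 1 `CNC1(COc2cccnc2)CC1` — 3 nM
compound 2 `CCNC1(COc2cccnc2)CC1` — 1010 nM

In an assay on brain for displacement of a labelled ligand from Neuronal acetylcholine receptor; alpha4/beta2 (Rattus norvegicus) (a higher number here means a weaker inhibitor, a lower number a stronger inhibitor), compound 1 gives 3 nM and compound 2 gives 1010 nM, the higher of the two numbers. For the measured compounds named here, the only measured step, a 340-fold higher number from compound 1 to compound 2 (2.53 log units; beyond the scatter), shows that a small enlargement of the group on the amine nitrogen costs a great deal of binding. Compound 3 `c1cncc(OCC2(N3CCCC3)CC2)c1` carries pyrrolidin-1-yl in place of ethylamino on a saturated ring carbon, a larger, ring-closed group in that position. Since enlargement hurt in a 340-fold higher number from compound 1 to compound 2 (2.53 log units; beyond the scatter), a further weakening is expected for compound 3, a 3.0-fold higher number from compound 2 to compound 3 (0.47 log units; beyond the scatter), though this rests on a single precedent. Compound 3 is therefore estimated at 3000 nM, within 500 nM to 20000 nM.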

Compound 3, inhibition constant: 1610 nM
Compound 3: middle estimate off by 1.9-fold (0.27 log units), on the high side; measured number inside the range.
By their numbers in this assay, from the lowest: compound 1; then compounds 2 and 3 (each within the scatter of the next).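

In this assay the ring-closed pyrrolidin-1-yl group and ethylamino cannot be told apart (a 1.6-fold higher number from compound 2 to compound 3 (0.20 log units; within the scatter)), even though pyrrolidin-1-yl has more heavy atoms and no hydrogen-bond donor. Against methylamino the large step remains (a 540-fold higher number from compound 1 to compound 3 (2.73 log units; beyond the scatter)), so among these three groups only methylamino gives a low number. Nothing measured here explains this. The compounds shown leave open how a primary amine, with two hydrogens on the nitrogen, or a dimethylamino group would compare.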